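The source may report more compounds than this note shows. Statements on the series, on what has been measured and on what is new or still open speak of the compounds shown alone.

Compounds measured so far in a functional assay on HCT-116 cells (Homo sapiens), read by MTT assay, with a stated time of 72 h (on this read-out higher numbers stand for weaker inhibition and lower numbers for stronger inhibition), are these:

- Compound 1 (`Nc1nc(N)c2c(-c3ccco3)cn([C@@H]3O[C@H](CO)[C@@H](O)[C@H]3O)c2n1`) gives > 20000 nM as a limit
- Compound 2 (`C#Cc1cn([C@@H]2O[C@H](CO)[C@@H](O)[C@H]2O)c2nc(C)nc(N)c12`) gives > 20000 nM as a limit
- Compound 3 (`COc1nc(N)nc2c1c(-c1ccco1)cn2[C@@H]1O[C@H](CO)[C@@H](O)[C@H]1O`) gives > 20000 nM as a limit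

Compound 3 therefore has no exact number, only a limit, and it shares that limit with the other two (the limit of > 20000 nM in this assay, at which 3 of the 3 values shown sit). Compound 4 (`COc1nc(N)nc2c1c(-c1cc3ccccc3o1)cn2[C@@H]1O[C@H](CO)[C@@H](O)[C@H]1O`) carries 1-benzofuran-2-yl in place of furan-2-yl on an aromatic carbon. Among the measured compounds shown here, the only measured step (a step that the two limits leave unreadable from compound 1 to compound 3) is a different change, methoxy in place of amino on an aromatic carbon, and it offers no size to carry over. No clear shift in either direction is therefore expected in this assay for this change (a number no higher from compound 3 to compound 4 (the limit leaves the size open)). Compound 4 is estimated at 20000 nM with a range of 5000 nM to 40000 nM around that estimate.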

Compound 4, half-maximal inhibitory concentration: > 20000 nM
Compound 4 was reported as a limit; the forecaster's own chance of this, stated with the estimate: 70%; the middle value lies on the limit itself.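

Compound 3 and compound 4 both stand only as limits, so no step between them can be read: the limit of > 20000 nM in this assay, at which 4 of the 4 values shown sit.

The compounds shown leave open how strongly any of them inhibits, and whether 1-benzofuran-2-yl in place of furan-2-yl changes that at all.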